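Piperidin-1-yl for methylsulfanyl in a weakly cytotoxic series

This account rests on a few compounds, and the source may have more. Where it says the series, first, only, none or still open, it means among the compounds named here.

In a functional assay on SK-MEL-28 cells (Homo sapiens) for cytotoxicity, read by MTT assay, with a stated time of 72 h (on this read-out lower numbers stand for stronger inhibition and higher numbers for weaker inhibition), the measured compounds read:
- Compound 1 `CCOC(=O)c1sc(N2CCCC2)nc1Cl` gives 82000 nM
- Compound 2 `O=C(c1ccccc1)c1sc(N2CCCCC2)nc1Br` gives 91000 nM
- Compound 3 `COC(=O)c1sc2nc(SC)sc2c1C` gives > 100000 nM as a limit

Compound 3 stands at the limit of > 100000 nM in this assay, at which 1 of the 3 values shown sits, and so has a limit and not a number. Compound 4 `COC(=O)c1sc2nc(N3CCCCC3)sc2c1C` has piperidin-1-yl in place of methylsulfanyl on an aromatic carbon and keeps the core of compound 3. The expectation rests on compound 2, which also carries piperidin-1-yl and gives 91000 nM on a different core. In this assay a modest step toward stronger inhibition is expected, estimated as an at least 1.4-fold lower number from compound 3 to compound 4 (0.15 log units; that floor lies within the scatter) from a starting point that is only a limit. For compound 4 the estimated value is 70000 nM with an expected range from 25000 nM to 100000 nM in this read-out.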

Compound 4, half-maximal inhibitory concentration: > 100000 nM
Compound 4 gave a limit, no number (the forecaster's own chance of this, stated with the estimate: 35%); at least 1.4-fold (0.15 log units) between middle value and limit.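

Compound 3 and compound 4 both give only a limit, so no step between them can be read: the limit of > 100000 nM in this assay, at which 2 of the 4 values shown sit.

On these data alone, what piperidin-1-yl in place of methylsulfanyl does to the read-out on the core of compound 3 stays open.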